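Swapping sulfamoyl for fluoro on a weak quinoline-acid series

The source may hold more compounds than are shown below. What is called first, only, known or untested is meant among the compounds shown, and "the series" means these compounds.

Measured so far:
compound 1 `O=C(O)c1ccc2c(O)c(C(=O)O)cnc2c1` — 1070000 nM
compound 2 `CN(C)c1ccc2c(O)c(C(=O)O)cnc2c1` — 479000 nM
compound 3 `NS(=O)(=O)c1ccc2c(O)c(C(=O)O)cnc2c1` — 955000 nM

All three compounds share one core and differ only in the group on the carbon-only ring of the fused system. In an assay on isolated protein with malate dehydrogenase, mitochondrial (Sus scrofa) as the target (on this read-out lower numbers stand for stronger inhibition and higher numbers for weaker inhibition), compound 3 gives the second highest of the three numbers. Its nearest neighbour is compound 1, which in this assay gives 1070000 nM; the furthest is compound 2, which gives 479000 nM. The step of a 2.0-fold higher number from compound 2 to compound 3 (0.30 log units; within the scatter) stays within the scatter, as does a 1.1-fold lower number from compound 1 to compound 3 (0.05 log units; within the scatter), while a 2.2-fold lower number from compound 1 to compound 2 (0.35 log units; beyond the scatter) is modest but beyond it. Every measured step at this position is therefore small, whatever the group.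

Compound 4 `O=C(O)c1cnc2cc(F)ccc2c1O` has not yet been measured. The change is fluoro in place of sulfamoyl on an aromatic carbon. Among the measured compounds shown here, no measured step exchanges a fluoro for anything, so the only guide is that exchanging sulfamoyl, carboxy and dimethylamino at this place moved the number by little. A step of comparable size is expected here, with no clear direction beyond the scatter, so compound 4 is estimated at 900000 nM (range 300000 nM to 3000000 nM), corresponding to a 1.1-fold lower number from compound 3 to compound 4 (0.03 log units; within the scatter).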

Compound 4, half-maximal inhibitory concentration: 10500000 nM
For compound 4 the middle estimate is 12-fold (1.07 log units) below the measured one; measured number outside the range, above it.
By their numbers in this assay, from the lowest: compounds 2, 3 and 1 (each within the scatter of the next, the first and the last beyond it); then compound 4.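

In this assay, this position proves not to be indifferent to the group it carries: fluoro in place of sulfamoyl gives an 11-fold higher number from compound 3 to compound 4 (1.04 log units; beyond the scatter), and replacing the other two groups gives a 22-fold higher number from compound 2 to compound 4 (1.34 log units; beyond the scatter) and a 9.8-fold higher number from compound 1 to compound 4 (0.99 log units; beyond the scatter). Carboxy, dimethylamino and sulfamoyl differ in many ways yet gave closely grouped numbers, so that similarity did not extend to every group, and compound 4 is the weakest of the four, with each of its steps beyond the scatter. The change removes a group of 4 heavy atoms with hydrogen-bond donors and acceptors and introduces a single fluorine atom with neither, but no measurement shown connects either difference to the loss of inhibition.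

Among the compounds shown here, with only one compound carrying fluoro, the data cannot show whether the higher number is particular to fluoro or shared by other groups at this place. A chloro, methyl or methoxy group here would help separate the number of heavy atoms from the hydrogen-bond counts, which change together in this single step.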